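Trifluoromethyl for methoxy beneath a shared limit

The source may report more compounds than this note shows. Statements on the series, on what has been measured and on what is new or still open speak of the compounds shown alone.

In a physicochemical assay for lipophilicity, at pH 7.4 (a lower number here means a more polar compound, a higher number a more lipophilic compound), compound 3 `COc1ccc(CNCCCC[C@@H](Nc2cc(C)c(F)c(C)c2)C(=O)NO)cc1` gives < 3 as a limit and not a number. Compound 1 `Cc1cc(CNCCCC[C@@H](Nc2cc(C)c(F)c(C)c2)C(=O)NO)ccc1F` gives < 3 as a limit too. Compound 2 `Cc1cc(N[C@H](CCCCNCc2ccccc2F)C(=O)NO)cc(C)c1F` gives < 3 as a limit too. Together they make up the limit of < 3 in this assay, at which 3 of the 3 values shown sit, and so none can be ranked against another.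

Compound 4 `Cc1cc(N[C@H](CCCCNCc2ccc(C(F)(F)F)cc2)C(=O)NO)cc(C)c1F` differs from compound 3 in one place, with trifluoromethyl in place of methoxy on an aromatic carbon para to a large group (trifluoromethyl in place of methoxy on an aromatic carbon). The same difference reads as 4-methoxyphenyl to 4-(trifluoromethyl)phenyl.

Three measured steps swap the aromatic group in this part of the molecule. They are a step that the two limits leave unreadable from compound 1 to compound 2 then a step that the two limits leave unreadable from compound 1 to compound 3 and also a step that the two limits leave unreadable from compound 2 to compound 3 and none of them has a size to carry over. They give no direction either.

Compound 3 stands at < 3 as a limit, and on that basis compound 4 is expected to stay at the same limit. The expected step is a step that the limit leaves unreadable from compound 3 to compound 4 and it may well remain unreadable. Compound 4 is estimated at 2.5 in this assay with an expected range from 1.8 to 3.2 and a report as a limit is the likeliest outcome.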

Compound 4, distribution coefficient: < 3
Compound 4 ended at the assay's limit (the forecaster's own chance of this, stated with the estimate: 80%); the middle value is on the limit's open side.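

In this assay compound 4 gives < 3, which is a limit and not a number. Among the compounds shown here, no step linking compound 4 to compound 1, compound 2 or compound 3 can be read, because all four compounds rest on one shared limit: the limit of < 3 in this assay, at which 4 of the 4 values shown sit. From the compounds shown here alone, whether trifluoromethyl in place of methoxy shifts the distribution coefficient at all, in which direction, and how the four compounds rank all stay open.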